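Swapping a Benzodioxin for Naphthalene in Sulfonamide Amines

This account rests on a few compounds, and the source may have more. Where it says the series, first, only, none or still open, it means among the compounds named here.

Two compounds sharing a bis(trifluoromethyl)benzenesulfonamide core have been tested so far. In a functional assay on BXPC-3 cells (Homo sapiens) for inhibition, read by MTT assay, with a stated time of 72 h (on this read-out higher numbers stand for weaker inhibition of growth and lower numbers for stronger inhibition of growth), compound 1 `O=S(=O)(NCCCNCC1COc2ccccc2O1)c1cc(C(F)(F)F)cc(C(F)(F)F)c1` gives 1200 nM, the lowest of the two numbers. Compound 2 `CN(CCCNS(=O)(=O)c1cc(C(F)(F)F)cc(C(F)(F)F)c1)Cc1ccccc1` gives 39000 nM in this assay, a number beyond the usual scatter from that of compound 1, though the two structures differ in more than one place, so no single cause can be read from the pair.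

Compound 3 `O=S(=O)(NCCCNCc1cccc2ccccc12)c1cc(C(F)(F)F)cc(C(F)(F)F)c1` has not yet been measured. It keeps the secondary amine and chain of compound 1 and differs only in that (naphthalen-1-yl in place of 2,3-dihydro-1,4-benzodioxin-2-yl on a saturated chain carbon bound to an amine nitrogen). Going by the values given here, since no measured pair shows this exact change, the step from compound 1 to compound 3 is expected to be modest, plausibly a small loss, and the estimated step is a 1.7-fold higher number from compound 1 to compound 3 (0.22 log units; within the scatter). On that basis, compound 3 is expected to give about 2000 nM in this assay, within a range of 500 nM to 8000 nM.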

Compound 3, concentration for 50% growth inhibition: 2700 nM
Compound 3: middle estimate off by 1.4-fold (0.13 log units), on the low side, within the range that was stated.
By their numbers in this assay, from the lowest: compound 1; then compound 3; then compound 2.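

In this assay, going by these compounds alone, naphthalen-1-yl in place of 2,3-dihydro-1,4-benzodioxin-2-yl gives a 2.3-fold higher number from compound 1 to compound 3 (0.35 log units; beyond the scatter), the first step here in which only one place changes. The step is modest even though the entering group has no oxygen atoms and no hydrogen-bond acceptors, so growth inhibition at this position does not require the two oxygen atoms of the leaving group. No measurement of any other property is available to explain the step.

Within the data shown here, the single swap changes the ring system and removes the oxygen atoms together, so the contribution of each remains unresolved. Naphthalen-2-yl would test the attachment point of the same ring system, while quinolin-4-yl would show how a ring nitrogen atom fares at this position.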